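The compounds below may be only part of what the source reports. "The series", "measured", "known", "first", "only" and "open" are said of these compounds alone.

Compound 1 `Cc1ccc(-c2nn(-c3ccccc3)cc2-c2nc3ccccc3n2S(=O)(=O)c2ccc(Cl)cc2)cc1`: 216000 nM
Compound 2 `O=S(=O)(c1ccccc1)n1c(-c2cn(-c3ccccc3)nc2-c2ccc(C(F)(F)F)cc2)nc2ccccc21`: 186000 nM
Compound 3 `COc1ccc(S(=O)(=O)n2c(-c3cn(-c4ccccc4)nc3-c3ccc(C(F)(F)F)cc3)nc3ccccc32)cc1`: 87400 nM

In an ADME assay on cells (Hepatocyte, Mus musculus) for cytotoxicity, read by MTT assay, with a stated time of 24 h (on this read-out higher numbers stand for lower toxicity in this test and lower numbers for higher toxicity in this test), compound 3 gives 87400 nM, the lowest of the three numbers, while compound 1 and compound 2 both stand clearly higher. The next compound to consider is compound 4 `O=S(=O)(c1ccc(Cl)cc1)n1c(-c2cn(-c3ccccc3)nc2-c2ccc(C(F)(F)F)cc2)nc2ccccc21`. It keeps everything in compound 3 except one group, which goes from 4-methoxyphenyl to 4-chlorophenyl, so chloro takes the place of methoxy on an aromatic carbon: chloro in place of methoxy on an aromatic carbon.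

Among the measured compounds shown here, one measured step bears directly on this change. Adding that same methoxy in place of hydrogen gave a 2.1-fold lower number from compound 2 to compound 3 (0.33 log units; beyond the scatter), a modest step but beyond the scatter. Compound 4 loses this methoxy, so its number may return towards that of compound 2. For the measured compounds named here, no measured step shows what chloro does in place of hydrogen, which leaves the estimate uncertain. Compound 1, which carries the 4-chlorophenyl group but differs elsewhere, gives 216000 nM and offers loose support for a number in that higher region.

The expected change is therefore modest and upward, an estimated 2.1-fold higher number from compound 3 to compound 4 (0.31 log units; beyond the scatter). Compound 4 is expected at about 180000 nM, with an estimated range from 95000 nM to 340000 nM.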

Compound 4, half-maximal cytotoxic concentration: 173000 nM
Compound 4: the middle estimate sits 1.0-fold (0.02 log units) above what was measured; low and high end bracket the measured number.
By their numbers in this assay, from the lowest: compounds 3, 4, 2 and 1 (each within the scatter of the next, the first and the last beyond it).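

In this assay, chloro in place of methoxy at this position gives a 2.0-fold higher number from compound 3 to compound 4 (0.30 log units; within the scatter), so this swap alone cannot be separated from the usual variation between repeat measurements. Among the compounds shown here, the comparison that the earlier compounds could not offer is with hydrogen at the same position, and it gives a 1.1-fold lower number from compound 2 to compound 4 (0.03 log units; within the scatter), so on this ring para to a large group, chloro and hydrogen cannot be told apart in this test, while the methoxy step from compound 2 to compound 3 remains the only one here beyond the scatter. The new compound also links the two changes on either side of the series, and trifluoromethyl in place of methyl on the other aromatic ring gives a 1.2-fold lower number from compound 1 to compound 4 (0.10 log units; within the scatter), so that swap cannot be told apart from the scatter either.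

As far as these compounds go, with only hydrogen, chloro and methoxy at this position, it remains open whether an amine, a carboxylic acid or a longer chain such as ethoxy would behave like methoxy or like chloro. Nothing among the data shown explains why methoxy alone gives a step beyond the scatter.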